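Swapping fluorine for hydroxyl on a thiazole alkyne

A few compounds are considered here, and "the series" means these few. Any claim that something is new, unique, unknown or untested is made for them only; others in the source may bear on it.

Among the measured compounds shown here, compound 1 `Cc1nc(C#Cc2cccc(F)c2)cs1` gives 23 nM in a functional assay on CHO cells for agonist activity at metabotropic glutamate receptor 5 (Homo sapiens), read by inositol phosphate accumulation (on this read-out higher numbers stand for weaker inhibition and lower numbers for stronger inhibition), the lower of the two numbers measured so far. Compound 2 `Cc1nc(C#Cc2cc(F)cc(F)c2)cs1` gives 25.3 nM in this assay, and the step of a 1.1-fold higher number from compound 1 to compound 2 (0.04 log units; within the scatter) shows that adding a second fluoro changes little. Compound 3 `Cc1nc(C#Cc2cccc(O)c2)cs1` differs from compound 1 by hydroxy in place of fluoro on an aromatic carbon. For the measured compounds named here, no measured step replaces fluoro with hydroxy, so the single measured step is only indirect guidance, and an exchange that introduces a hydrogen-bond donor may cost some potency. Compound 3 is expected to give 60 nM, within 15 nM to 250 nM, a step of a 2.6-fold higher number from compound 1 to compound 3 (0.42 log units; beyond the scatter) expected from compound 1 to compound 3.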

Compound 3, half-maximal inhibitory concentration: 654 nM
For compound 3 the middle estimate is 11-fold (1.04 log units) below the measured one; measured number above the stated range.
By their numbers in this assay, from the lowest: compounds 1 and 2 (each within the scatter of the next); then compound 3.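

Among the compounds shown here, until now the only change was an added fluoro, which left the number nearly unchanged. Replacing the fluoro of compound 1 with hydroxy gives a 28-fold higher number from compound 1 to compound 3 (1.45 log units; beyond the scatter) in this assay, so this position on the ring is sensitive to which group sits there, even though the two groups are each a single heavy atom. Nothing measured here explains why the number rises. Going by these compounds, whether a methoxy or an amine at this place would behave more like fluoro or like hydroxy remains open, and so does the question of whether the hydrogen-bond donor of hydroxy matters.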